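The source may report more compounds than this note shows. Statements on the series, on what has been measured and on what is new or still open speak of the compounds shown alone.

Working notes on the series. For the measured compounds named here, compound 2 `C=CCC(C)(C)C(NC(=O)c1ccc(Cl)cc1)N/C(=N/c1cccnc1)NC#N` gives 20000 nM in a functional assay with sulfonylurea receptor 2, Kir6.2 (Homo sapiens) as the target (on this read-out lower numbers stand for an effect already at smaller amounts and higher numbers for an effect only at larger amounts of compound), and stands highest of the two numbers measured so far; the nearest is compound 1 `CC(C)(C)C(NC(=O)c1ccc(Cl)cc1)N/C(=N/c1cccnc1)NC#N`, which in this assay gives 6310 nM. Going by the values given here, the one step measured between them is a 3.2-fold higher number from compound 1 to compound 2 (0.50 log units; beyond the scatter), where vinyl replaced hydrogen on the saturated chain carbon three bonds along the chain from the amide-type nitrogen and the amine nitrogen. Compound 3 `CCCCC(C)(C)C(NC(=O)c1ccc(Cl)cc1)N/C(=N/c1cccnc1)NC#N` has not been measured. It differs from compound 2 by propyl in place of vinyl on a saturated chain carbon, three bonds along the chain from an amide-type nitrogen and an amine nitrogen. Among the compounds with values here, the only measured step that bears on this place is the one from compound 1 to compound 2, and it moved the number modestly upward when the chain at this carbon grew; the change to compound 3 grows the same chain again while removing the double bond, and no measured pair shows what saturation alone does here. The expectation is therefore a step of a 1.3-fold higher number from compound 2 to compound 3 (0.10 log units; within the scatter), small and of uncertain direction, likely within or just beyond the scatter. Compound 3 is estimated at 25000 nM, with a range from 10000 nM to 60000 nM.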

Compound 3, half-maximal effective concentration: < 100000 nM
Compound 3 ended at the assay's limit; the forecaster's own chance of this, stated with the estimate: 25%; the middle value is on the limit's open side.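

In this assay compound 3 gives < 100000 nM, which is a limit of the assay and not a number. The steps to compound 3 from compound 1 and compound 2 therefore cannot be read: the limit of < 100000 nM in this assay, at which 1 of the 3 values shown sits. The compounds shown leave open how propyl in place of vinyl on this saturated chain carbon moves the number in this assay.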